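This account rests on a few compounds, and the source may have more. Where it says the series, first, only, none or still open, it means among the compounds named here.

Measured so far:
compound 1 `COc1ccc(/C=C/S(=O)(=O)Nc2c(F)c(F)c(F)c(F)c2F)cc1N`: 35000 nM
compound 2 `COc1cc(OC)c(/C=C/S(=O)(=O)Nc2ccc(OC)c(OP(=O)(O)O)c2)c(OC)c1`: 40 nM

In a functional assay on DU-145 cells (Homo sapiens) for cytotoxicity, read by trypan blue exclusion, with a stated time of 96 h (on this read-out lower numbers stand for stronger inhibition and higher numbers for weaker inhibition), compound 2 gives the lowest of the two numbers; compound 1 stands far higher, a gap beyond the usual scatter. Compound 3 `COc1cc(OC)c(/C=C/S(=O)(=O)Nc2ccc(OC)c(NC(C(=O)O)c3ccccc3)c2)c(OC)c1` is not yet measured. It differs from compound 2 in one place: a group of 11 heavy atoms (8 carbon, 1 nitrogen, 2 oxygen; one six-membered aromatic ring of carbon only) in place of a group of 5 heavy atoms (4 oxygen, 1 phosphorus; no ring), on an aromatic carbon. Going by the values given here, no measured pair shows such a change, so there is nothing to calibrate the size of the step in this assay. A moderate rise in the number, with wide uncertainty in either direction, is expected here, as a 5.0-fold higher number from compound 2 to compound 3 (0.70 log units; beyond the scatter). Compound 3 is therefore estimated at 200 nM, within 30 nM to 2000 nM.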

Compound 3, half-maximal inhibitory concentration: 75 nM
Beside the measured number, compound 3's estimate is 2.7-fold (0.43 log units) above it; low and high end bracket the measured number.
By their numbers in this assay, from the lowest: compounds 2 and 3 (each within the scatter of the next); then compound 1.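

Placing (carboxy(phenyl)methyl)amino on this aromatic carbon, ortho to a methoxy group, instead of the phosphorus-containing group gives a 1.9-fold higher number from compound 2 to compound 3 (0.27 log units; within the scatter) in this assay. Going by these compounds alone, this position therefore accommodates a group with a six-membered aromatic ring as well as one with no ring, something no earlier pair could show. No measurement here accounts for this result. From the compounds shown here alone, it remains open whether the carboxylic acid or the phenyl ring of the new group matters, and what a plain hydroxyl group or a methyl ester would give here.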